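Ortho Methyl for Ortho Chloro on the Amide-Nitrogen Aryl

This account rests on a few compounds, and the source may have more. Where it says the series, first, only, none or still open, it means among the compounds named here.

Compound 1 `O=C1CC(c2nc(-c3cccc(Cl)c3)no2)CN1c1ccccc1Cl` gives > 10000 nM in an in vitro functional assay on HEK293-A cells for positive allosteric modulation of metabotropic glutamate receptor 5 (Homo sapiens), read by FLIPR and calcium flux (a higher number here means that more compound is needed for the effect, a lower number that less compound is needed), which is a limit of the assay and not a number.
Compound 2 `O=C1CC(c2nc(-c3cccc(F)c3)no2)CN1c1ccc(F)cc1` gives 88 nM in this assay.
Compound 3 `O=C1CC(c2nc(-c3cccc(F)c3)no2)CN1c1ccc(Cl)c(Cl)c1` gives 3200 nM in this assay.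

Among the three measured compounds, compound 1 stands at the limit of this assay (the limit of > 10000 nM in this assay, at which 1 of the 3 values shown sits), so its own value is known only as a bound. Compound 2 and compound 3 differ in one place, and that step a 36-fold higher number from compound 2 to compound 3 (1.56 log units; beyond the scatter) is the only one measured here. Compound 4 `Cc1ccccc1N1CC(c2nc(-c3cccc(Cl)c3)no2)CC1=O` differs from compound 1 by methyl in place of chloro on an aromatic carbon. Among the compounds with values here, no measured step touches this position: the one measured step changes the substitution pattern of the same aryl ring elsewhere, and it says nothing about a methyl replacing a chloro. Compound 1 itself offers no number to start from. The expectation for compound 4 therefore rests on little, and the step of an at least 1.1-fold lower number from compound 1 to compound 4 (0.04 log units; that floor lies within the scatter) is estimated as no more than a modest change, quite possibly none beyond the scatter. Compound 4 is expected to give about 9000 nM in this assay, with a wide range from 1500 nM to 30000 nM, and a real chance that it, too, is reported only as a limit.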

Compound 4, half-maximal effective concentration: > 10000 nM
Compound 4: no number, only a limit (the forecaster's own chance of this, stated with the estimate: 55%); middle value at least 1.1-fold (0.04 log units) away from the limit.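

Within the data shown here, compound 1 and compound 4 both stand at a limit of the assay and not at a number, so no step between them can be read: the limit of > 10000 nM in this assay, at which 2 of the 4 values shown sit.

The compounds shown leave open whether methyl in place of chloro on an aromatic carbon changes the value in this assay at all, and by how much.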